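Benzyl replaces phenyl on the ring nitrogen: compound 4

The compounds below may be only part of what the source reports. "The series", "measured", "known", "first", "only" and "open" are said of these compounds alone.

Measured so far:
compound 1 `CC(C)N1C(=O)NC2(CC2c2ccc3cccc(OCc4ccccc4)c3n2)C1=O`: 100 mg/kg
compound 2 `O=C1NC2(CC2c2ccc3cccc(OCc4ccccc4)c3n2)C(=O)N1c1ccc(Br)cc1`: 300 mg/kg
compound 3 `O=C1NC2(CC2c2ccc3cccc(OCc4ccccc4)c3n2)C(=O)N1c1ccccc1`: 300 mg/kg

All three compounds were tested in a functional assay on the whole organism (strain Kunming) with Mus musculus as the target, in the maximal electroshock model, with a stated time of 4 h; a lower number here means that less compound is needed, a higher number that more compound is needed for the effect. Compound 3 stands level with compound 2 at the digits reported, the step of no change at the digits printed from compound 2 to compound 3 (within the scatter) lying within the scatter; together these two give the highest numbers of the three. Compound 1 gives the lowest number, and the step of a 3.0-fold higher number from compound 1 to compound 3 (0.48 log units; beyond the scatter) is beyond the scatter, as is a 3.0-fold higher number from compound 1 to compound 2 (0.48 log units; beyond the scatter). Compound 4 `O=C1NC2(CC2c2ccc3cccc(OCc4ccccc4)c3n2)C(=O)N1Cc1ccccc1` differs from compound 3 in one place: benzyl in place of phenyl on an amide-type nitrogen in a ring.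

Within the data shown here, the steps that bear on this change are those at the same ring nitrogen, a 3.0-fold higher number from compound 1 to compound 3 (0.48 log units; beyond the scatter) and a 3.0-fold higher number from compound 1 to compound 2 (0.48 log units; beyond the scatter), both modest, while replacing bromo by hydrogen on the aromatic ring left the number unchanged. Among the measured compounds shown here, no measured step shows a benzyl at this nitrogen, so the direction of the new step is uncertain. A modest step downward is expected in this assay for compound 4, a 1.8-fold lower number from compound 3 to compound 4 (0.25 log units; within the scatter), given that compound 1 with isopropyl gave 100 mg/kg. The estimate for compound 4 is 170 mg/kg, within a range from 80 mg/kg to 350 mg/kg.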

Compound 4, minimum effective dose: 300 mg/kg
The estimate for compound 4 lay 1.8-fold (0.25 log units) below the measured number; measured number inside the range.
By their numbers in this assay, from the lowest: compound 1; then compounds 2, 3 and 4 (each within the scatter of the next).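

Benzyl on the ring nitrogen reads the same as phenyl in this assay (no change at the digits printed from compound 3 to compound 4 (within the scatter)) and the same as 4-bromophenyl (no change at the digits printed from compound 2 to compound 4 (within the scatter)). Placing benzyl rather than phenyl on this nitrogen therefore does not recover the lower number of the isopropyl compound (a 3.0-fold higher number from compound 1 to compound 4 (0.48 log units; beyond the scatter)). Among the four compounds, isopropyl is the only group at this nitrogen set apart by a step beyond the scatter, while the three groups carrying an aromatic ring stay together. Nothing available here explains why these three read alike or why isopropyl differs.

On these data alone, it remains open whether the number would fall further with a small group such as methyl or ethyl, or with a plain hydrogen on this nitrogen. As far as these compounds go, the effect of a longer chain, such as butyl, or of a chain ending in an amine is also open.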